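Hydrazone aryl variation in an acrylamide-bearing pyrimidine series

The source may hold more compounds than are shown below. What is called first, only, known or untested is meant among the compounds shown, and "the series" means these compounds.

Measured compounds:
- compound 1: `CN(C)C/C=C/C(=O)Nc1cccc(Nc2nc(N/N=C/c3ccc(F)cc3F)ncc2Cl)c1`, 2920 nM in an ADME assay on HT-29 cells (Homo sapiens) for inhibition, read by MTT assay, with a stated time of 72 h; on this read-out higher numbers stand for weaker inhibition and lower numbers for stronger inhibition
- compound 2: `C/C(=N\Nc1ncc(Cl)c(Nc2cccc(NC(=O)/C=C/CN(C)C)c2)n1)c1ccc(F)cc1`, 10200 nM in this assay
- compound 3: `C/C(=N\Nc1ncc(Cl)c(Nc2cccc(NC(=O)/C=C/CN(C)C)c2)n1)c1ccccn1`, 120 nM in this assay

Compound 3 gives the lowest number of the three in this assay; its nearest neighbour is compound 1, and compound 2 lies furthest from it. The steps that lead to it are both large: a 24-fold lower number from compound 1 to compound 3 (1.39 log units; beyond the scatter) and an 85-fold lower number from compound 2 to compound 3 (1.93 log units; beyond the scatter). The aryl group on the hydrazone carbon is therefore the one position in this set where changes move the read-out well beyond the scatter, while a 3.5-fold higher number from compound 1 to compound 2 (0.54 log units; beyond the scatter) is only modest.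

Compound 4 is `C/C(=N\Nc1ncc(Cl)c(Nc2cccc(NC(=O)/C=C/CN(C)C)c2)n1)c1ccncc1`. It differs from compound 3 in one place: pyridin-4-yl in place of pyridin-2-yl on a carbon with a double bond to nitrogen. For the measured compounds named here, no measured step moves a ring nitrogen within an otherwise unchanged ring, so the two steps into compound 3 bear on it only indirectly: they show that this aryl group matters greatly, and that compound 3 holds the single arrangement found so far that gives a low number. The change to compound 4 is expected to move the number upward, toward the range of compound 1 and compound 2, so a step of about a 13-fold higher number from compound 3 to compound 4 (1.10 log units; beyond the scatter) is estimated. For compound 4 the expected value in this assay is 1500 nM, with a range from 300 nM to 8000 nM.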

Compound 4, half-maximal inhibitory concentration: 10900 nM
The estimate for compound 4 lay 7.3-fold (0.86 log units) below the measured number; the whole stated range lies below it.
By their numbers in this assay, from the lowest: compound 3; then compound 1; then compounds 2 and 4 (each within the scatter of the next).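

In this assay, the pyridine ring alone does not give a low number: with the same atoms joined differently, a 91-fold higher number from compound 3 to compound 4 (1.96 log units; beyond the scatter) is a large step, so the low number in this small set belongs to the pyridin-2-yl arrangement and not to pyridine rings in general. The pyridin-4-yl group gives no separation from the 4-fluorophenyl group on the same carbon with a double bond to nitrogen, as a 1.1-fold higher number from compound 2 to compound 4 (0.03 log units; within the scatter) stays within the scatter, so the ring nitrogen in compound 4 brings no measurable gain over the fluorinated carbon ring of compound 2. The remaining step, a 3.7-fold higher number from compound 1 to compound 4 (0.57 log units; beyond the scatter), is modest and places compound 4 with compound 2 at the high end of the series, leaving compound 3 alone at the low end among the aryl groups shown.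

The compounds shown give no measurement that accounts for the gap between the pyridin-2-yl and pyridin-4-yl groups. Also open, from the compounds shown here alone, is where pyridin-3-yl would fall, and whether the low number of compound 3 survives a pyrimidin-2-yl ring or a hydrogen in place of the methyl group on the hydrazone carbon.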